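Series notes: alkyne substituent change at the core

The source may hold more compounds than are shown below. What is called first, only, known or untested is meant among the compounds shown, and "the series" means these compounds.

Measured so far, in a functional assay on MCF7 cells (Homo sapiens) for inhibition, read by sulforhodamine B assay, with a stated time of 48 h; a lower number here means a stronger inhibitor of growth, a higher number a weaker inhibitor of growth:
- compound 1 `COC(=O)c1sc2cc(C#Cc3ccccn3)cnc2c1N`; in this assay compound 1 gives 37400 nM.
- compound 2 `COC(=O)c1sc2cc(C#Cc3ccccc3OC)cnc2c1N`; in this assay compound 2 gives > 47300 nM, which is a limit, not a number.
- compound 3 `COC(=O)c1sc2cc(C#Cc3cccnc3)cnc2c1N`; in this assay compound 3 gives > 150000 nM, which is a limit, not a number.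

Compound 3 thus stands only at a limit of this assay (the limit of > 150000 nM in this assay, at which 1 of the 3 values shown sits); the step of an at least 4.0-fold higher number from compound 1 to compound 3 (0.60 log units; beyond the scatter) is beyond the scatter, while the step that the two limits leave unreadable from compound 2 to compound 3 cannot be read, since compound 2 also sits at a limit (the limit of > 47300 nM in this assay, at which 1 of the 3 values shown sits).

Compound 4 `COC(=O)c1sc2cc(C#Cc3ccccc3N)cnc2c1N` has not been measured. It differs from compound 3 by 2-aminophenyl in place of pyridin-3-yl on a triple-bonded carbon. Among the measured compounds shown here, two measured steps bear on this change: the step of an at least 4.0-fold higher number from compound 1 to compound 3 (0.60 log units; beyond the scatter), which shows that a ring with the nitrogen moved within the pyridine weakens growth inhibition, and the step of an at least 1.2-fold higher number from compound 1 to compound 2 (0.10 log units; that floor lies within the scatter), whose floor lies within the scatter, for the other 2-substituted phenyl in the set. Neither step shows a 2-substituted phenyl on the alkyne reaching a readable number. In this assay compound 4 is therefore expected to sit near or above the measurable range, the expected step being an at least 2.5-fold lower number from compound 3 to compound 4 (0.39 log units; beyond the scatter). The estimate for compound 4 in this assay is 60000 nM, with a range from 15000 nM to 200000 nM.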

Compound 4, concentration for 50% growth inhibition: 4100 nM
Compound 4: the middle estimate sits 15-fold (1.17 log units) above what was measured; the measured number lies below the stated range.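

In this assay, 2-aminophenyl on the triple-bonded carbon gives a 9.1-fold lower number from compound 1 to compound 4 (0.96 log units; beyond the scatter), so this position can carry a group that improves on the pyridin-2-yl of compound 1. Amino in place of methoxy on an aromatic carbon gives an at least 11-fold lower number from compound 2 to compound 4 (1.06 log units; beyond the scatter), so among these two compounds, which share the phenyl ring, the outcome turns on the group on that ring and a 2-substituted phenyl is not tied to weak growth inhibition; this step is only a floor, with compound 2 at a limit and not a number: the limit of > 47300 nM in this assay, at which 1 of the 4 values shown sits. Against pyridin-3-yl the change gives an at least 36-fold lower number from compound 3 to compound 4 (1.56 log units; beyond the scatter), again only a floor, with compound 3 at a limit and not a number: the limit of > 150000 nM in this assay, at which 1 of the 4 values shown sits.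

The compounds shown leave open whether the gain depends on the free amino group's hydrogens, which 2-(methylamino)phenyl, 2-(dimethylamino)phenyl or 2-hydroxyphenyl on the alkyne would test. They also leave open whether the amino group must sit where it does in compound 4, which 3-aminophenyl and 4-aminophenyl would settle.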